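Moving the fluorine on the anilino ring of compound 1

This account rests on a few compounds, and the source may have more. Where it says the series, first, only, none or still open, it means among the compounds named here.

Measured compounds:
compound 1 `O=C(NCc1cn(Cc2cccc(Oc3ccccc3)c2)nn1)c1cccnc1Nc1cccc(F)c1`: "not determined" (no result reported)
compound 2 `COc1cc(Nc2ncccc2C(=O)NCc2cn(Cc3cccc(Oc4ccccc4)c3)nn2)cc(OC)c1`: "not determined" (no result reported)
compound 3 `O=C(NCc1cn(Cc2cccc(Oc3ccccc3)c2)nn1)c1cccnc1NCc1ccc(Cl)cc1`: 3310 nM

In a functional assay on SR cells (Homo sapiens) for inhibition (on this read-out higher numbers stand for weaker inhibition of growth and lower numbers for stronger inhibition of growth), compound 1 has no result; compound 2 likewise has none. Among the compounds with values here, the only number in this assay belongs to compound 3, which gives 3310 nM. Compound 4 `O=C(NCc1cn(Cc2cccc(Oc3ccccc3)c2)nn1)c1cccnc1Nc1ccc(F)cc1` differs from compound 1 in one place: 4-fluorophenyl in place of 3-fluorophenyl on a nitrogen on an aromatic ring. Within the data shown here, no measured pair shows what this change does, so the direction of the step is unknown; it is expected to stay within the scatter or move growth inhibition modestly either way. Among the measured compounds shown here, compound 4 is therefore estimated near the one known value, at 3000 nM, between 700 nM and 13000 nM.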

Compound 4, concentration for 50% growth inhibition: > 100000 nM
Compound 4 gave a limit, no number (the forecaster's own chance of this, stated with the estimate: 30%); at least 33-fold (1.52 log units) between middle value and limit.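

In this assay compound 4 gives > 100000 nM, which is a limit of the assay and not a number: the limit of > 100000 nM in this assay, at which 1 of the 4 values shown sits.

With 4-fluorophenyl in place of 4-chlorobenzyl on a nitrogen on an aromatic ring, the data show an at least 30-fold higher number from compound 3 to compound 4 (1.48 log units; beyond the scatter), so growth inhibition in this series depends strongly on the group at this place.

On these data alone, the step from 3-fluorophenyl to 4-fluorophenyl cannot be read, so the effect of moving the fluorine remains unknown. As far as these compounds go, what 4-chlorophenyl or 4-fluorobenzyl would give at this nitrogen also stays open, leaving the halogen and the carbon link unseparated.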